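The source may hold more compounds than are shown below. What is called first, only, known or untested is meant among the compounds shown, and "the series" means these compounds.

Compound 1 `O=c1cc(CSc2nc3ccccc3s2)oc2ccc(Cl)cc12` gives > 25000 nM in a functional assay on SW480 cells (Homo sapiens) for cytotoxicity, read by MTT assay, with a stated time of 72 h; on this read-out higher numbers stand for weaker inhibition and lower numbers for stronger inhibition.
Compound 2 `Cc1nnc(SCc2cc(=O)c3ccccc3o2)s1` gives > 25000 nM in this assay.
Compound 3 `Cc1ccc2oc(CSc3nc4nc(C)cc(C)n4n3)cc(=O)c2c1` gives > 25000 nM in this assay.

Each of these three readings is a limit of the assay rather than a measured number. For compound 2 the reading > 25000 nM marks the limit, so the compound shows no cytotoxic effect up to that point. The same holds for compound 1, whose reading > 25000 nM is a limit. Compound 3 likewise reaches only a limit, > 25000 nM. All three readings share one feature: the limit of > 25000 nM in this assay, at which 3 of the 3 values shown sit. Going by the values given here, no step between two measured compounds can be given a size here, since none of them yields a number.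

Compound 4 `Cc1nnc(SCc2cc(=O)c3ccccc3o2)o1` is the untested partner of compound 2. The change is 5-methyl-1,3,4-oxadiazol-2-yl in place of 5-methyl-1,3,4-thiadiazol-2-yl on a sulfur. Both groups keep the same count of heavy atoms, donors and acceptors, and the rest of the structure is untouched.

Because compound 2 gives > 25000 nM and the other two compounds also stop at the limit, compound 4 is expected to remain at or near that limit as well. The step that the limit leaves unreadable from compound 2 to compound 4 is expected to be none beyond the scatter. Compound 4 is therefore estimated at 30000 nM, within a range from 10000 nM to 100000 nM, most likely reported again only as a limit.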

Compound 4, half-maximal inhibitory concentration: > 25000 nM
Compound 4: a limit, no number; the forecaster's own chance of this, stated with the estimate: 85%; the middle value is on the limit's open side.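

No step can be read from compound 2 to compound 4, since both readings are limits of the assay rather than numbers: the limit of > 25000 nM in this assay, at which 4 of the 4 values shown sit.

The compounds shown leave open what structure would give a measurable number in this assay, and how 5-methyl-1,3,4-oxadiazol-2-yl compares with 5-methyl-1,3,4-thiadiazol-2-yl on a sulfur.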